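From an acid-bearing chain to a dimethylamide chain

The source may report more compounds than this note shows. Statements on the series, on what has been measured and on what is new or still open speak of the compounds shown alone.

Measured compounds:
compound 1, `CC(=O)c1cc(CC2CO2)c(OCCCCC#N)cc1O`, gives 62%
compound 2, `CC(=O)c1cc(C(C)(C)C)c(OCCCCCC(C)(C)C#N)cc1O`, gives 1%
compound 3, `CCc1cc(C(C)=O)c(O)cc1OCCCC(C)(C)C(=O)O`, gives 89%

These three compounds were tested in an assay on isolated protein for inhibition of leukotriene B4 receptor 1 (Homo sapiens), tested at 10 uM; on this read-out higher numbers stand for more inhibition at the one concentration tested (going by the name of the read-out) and lower numbers for less inhibition. Compound 3 stands highest of the three numbers. Its nearest neighbour is compound 1, whose number lies lower by a gap beyond the usual scatter, and its furthest is compound 2, whose number lies lower by a much larger gap, also beyond the scatter. Going by the values given here, no two of the measured compounds differ in a single place, so no step between them can be read as the effect of one change.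

Compound 4, `CCc1cc(C(C)=O)c(O)cc1OCCCCCCC(=O)N(C)C`, has not yet been measured in this assay. It differs from compound 3 in one place: 3-(dimethylcarbamoyl)propyl in place of 1-carboxy-1-methylethyl on a saturated chain carbon, three bonds along the chain from an oxygen on an aromatic ring.

Compound 1 and compound 2 carry no carboxy group on their chains and both give lower numbers than compound 3, though each also differs from compound 3 elsewhere. On that basis the step of a number 44 percentage points lower from compound 3 to compound 4 (beyond the scatter) is expected to run downward and to go beyond the scatter. Compound 4 is estimated to give 45% in this assay, within a range from 15% to 75%.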

Compound 4, a percentage reported as inhibition, at one concentration (the size of the read-out at that concentration, not a potency): 100%
The estimate for compound 4 lay 55 percentage points below the measured number; measured number outside the range, above it.
By their numbers in this assay, from the lowest: compound 2; then compound 1; then compound 3; then compound 4.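

In this assay, 3-(dimethylcarbamoyl)propyl in place of 1-carboxy-1-methylethyl on a saturated chain carbon, three bonds along the chain from an oxygen on an aromatic ring, gives a number 11 percentage points higher from compound 3 to compound 4 (beyond the scatter). This is the first single change among these compounds, and it shows that on the shared core this position accepts a group with no carboxy function and no hydrogen-bond donor, and with more heavy atoms than the group it replaces, without any loss on this read-out; compound 1 and compound 2 could not show this, as each differs from the others in more than one place. Nothing available explains why the number moves in this direction.

The step changes the end group and the chain together, so it remains open which of the two accounts for it; a carboxylic acid at the end of the same longer chain, or a dimethylamide on the shorter chain with its two methyl groups, would separate them. A read-out at one concentration also leaves open how compound 3 and compound 4 compare in potency.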